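This account rests on a few compounds, and the source may have more. Where it says the series, first, only, none or still open, it means among the compounds named here.

Notes on the series. Going by the values given here, in a functional assay on U2OS cells with metabotropic glutamate receptor 5 (Homo sapiens) as the target, read by calcium flux (on this read-out lower numbers stand for smaller maximal responses and higher numbers for larger maximal responses), compound 3 `CC(C)(C)n1nnc2c1CCC(c1nc(C3CCCCC3)no1)C2` gives 91%, the highest of the three numbers measured so far. Compound 2 `Cc1ccc(-c2noc(C3CCc4c(nnn4C(C)(C)C)C3)n2)cn1` gives 67%, and compound 1 `Fc1ccc(-c2nc(-c3ccc4c(c3)nnn4C3CCCC3)no2)cc1` gives 51%; both of these lie beyond the scatter below compound 3. Among the compounds with values here, only one measured step changes a single place: a number 24 percentage points higher from compound 2 to compound 3 (beyond the scatter), which raised the maximal response when a saturated ring replaced an aromatic one on the shared core. Compound 4 `CN(C)c1ccc(-c2noc(C3CCc4c(nnn4C(C)(C)C)C3)n2)cc1` undoes that kind of change: 4-(dimethylamino)phenyl in place of cyclohexyl on an aromatic carbon. Within the data shown here, no measured step covers this exact pair, but the step from compound 2 to compound 3 bears on it in the opposite direction, so a drop of roughly that size, beyond the scatter, is expected in this assay rather than a flat result. Compound 4 is therefore expected to give 65%, with a range from 45% to 85%. That estimate corresponds to an expected step of a number 26 percentage points lower from compound 3 to compound 4 (beyond the scatter).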

Compound 4, largest response reached (reported as percent of maximum), in percent of the reference or control that the assay uses: 68%
Compound 4: middle estimate off by 3 percentage points, on the low side; low and high end bracket the measured number.
By their numbers in this assay, from the lowest: compound 1; then compounds 2 and 4 (each within the scatter of the next); then compound 3.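

In this assay, the position on the aromatic carbon of the five-membered aromatic ring with 2 nitrogen and 1 oxygen now carries three groups on the shared core, and the step of a number 23 percentage points lower from compound 3 to compound 4 (beyond the scatter) shows that cyclohexyl stands above a second aromatic group, not only above 6-methylpyridin-3-yl. The step of a number 1 percentage points higher from compound 2 to compound 4 (within the scatter) leaves 4-(dimethylamino)phenyl and 6-methylpyridin-3-yl indistinguishable on this read-out, so among these three compounds the split falls between the saturated ring and the two aromatic rings. Nothing available explains this split.

Going by these compounds, the advantage rests on cyclohexyl alone, so it stays open whether it extends to other saturated rings or depends on a ring at all. A piperidin-4-yl group or an open n-hexyl chain at this position would address both questions.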